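Dropping One Methoxy Group From Compound 2

This account rests on a few compounds, and the source may have more. Where it says the series, first, only, none or still open, it means among the compounds named here.

Among the compounds with values here, compound 2 `COc1ccc(/C(=C\c2cn(C(C)=O)c3ccc(OCc4ccccc4)cc23)C(=O)O)cc1OC` is the only member of this small set for which a functional assay on KB cells (Homo sapiens) for cytotoxicity, read by MTT assay, with a stated time of 72 h (on this read-out higher numbers stand for weaker inhibition and lower numbers for stronger inhibition), returns a number: in this assay compound 2 gives 96700 nM. Its partner, compound 1 `CC(=O)n1cc(/C=C(/C(=O)O)c2ccc(Cl)cc2)c2cc(OCc3ccccc3)ccc21`, carries a 4-chlorophenyl group where compound 2 carries a 3,4-dimethoxyphenyl group. For compound 1 this assay reports only a limit, > 100000 nM, not a number. Within the data shown here, the single measured step, an at least 1.0-fold lower number from compound 1 to compound 2 (0.01 log units; that floor lies within the scatter), exchanges the whole aryl group and still stays within the scatter; the only other point of reference is the limit of > 100000 nM in this assay, at which 1 of the 2 values shown sits.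

Compound 3 `COc1ccc(/C(=C\c2cn(C(C)=O)c3ccc(OCc4ccccc4)cc23)C(=O)O)cc1` differs from compound 2 by hydrogen in place of methoxy on an aromatic carbon. This change sits inside the same aryl group that was swapped wholesale in the measured step, and that step moved the number no further than the scatter allows. Among the measured compounds shown here, nothing among the measured compounds points to a larger effect from removing one methoxy group. Compound 3 is therefore expected to show no step beyond the scatter in this assay, with a real chance that only a limit is reported again. Compound 3 is estimated at 100000 nM, between 40000 nM and 300000 nM. This estimate means an expected 1.0-fold higher number from compound 2 to compound 3 (0.01 log units; within the scatter).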

Compound 3, half-maximal inhibitory concentration: > 100000 nM
Compound 3 was reported as a limit; the forecaster's own chance of this, stated with the estimate: 50%; the middle value sits exactly at the limit.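

Removing one methoxy group, the change from 3,4-dimethoxyphenyl to 4-methoxyphenyl, gives an at least 1.0-fold higher number from compound 2 to compound 3 (0.01 log units; that floor lies within the scatter) in this assay and so marks only a floor for this change, with neither a real loss nor its absence shown at this aromatic carbon ortho to a methoxy group. The earlier compounds shown here compared only whole aryl groups, whereas this result isolates one methoxy group and shows that the 4-methoxyphenyl compound, like the 4-chlorophenyl compound, is reported only as a limit, so the step from compound 1 to compound 3 cannot be read. Within the data shown here, compound 2 therefore remains the only compound with an actual number, and the limit now accounts for most of the set: the limit of > 100000 nM in this assay, at which 2 of the 3 values shown sit.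

From the compounds shown here alone, how far compound 3 truly lies from compound 2 remains open, since its value is only a limit and not a number. Also open, going by these compounds, is whether a hydroxy group, an amine or a longer alkoxy chain on the same aromatic carbon would give a value clearly beyond the scatter from compound 2 in this assay.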